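The source may hold more compounds than are shown below. What is called first, only, known or untested is meant among the compounds shown, and "the series" means these compounds.

Measured so far in a functional assay on the whole organism (strain albino) with Rattus norvegicus as the target, in the maximal electroshock model, with a stated time of 1 h, at a dose of 30 mg/kg by the intraperitoneal route; on this read-out higher numbers stand for more inhibition at the one dose given (going by the name of the read-out) and lower numbers for less inhibition:

compound 1 `Cc1nc2ccccc2c(=O)n1NCc1nnc(/N=C/c2ccc(N(C)C)cc2)s1` — 50%
compound 2 `COc1ccc(/C=N/c2nnc(CNn3c(C)nc4ccccc4c3=O)s2)cc1` — 50%
compound 3 `Cc1nc2ccccc2c(=O)n1NCc1nnc(/N=C/c2ccc(O)cc2)s1` — 50%

The three share one core and differ only in the group on the aromatic carbon para to the large group. Compound 3 stands level with compound 1 and compound 2 at the digits shown; the step of no change at the digits printed from compound 1 to compound 3 (within the scatter) and the step of no change at the digits printed from compound 2 to compound 3 (within the scatter) both lie within the scatter, as does no change at the digits printed from compound 1 to compound 2 (within the scatter). Nothing in these three numbers separates a dimethylamino, a methoxy or a hydroxy at that position.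

Compound 4 `Cc1nc2ccccc2c(=O)n1NCc1nnc(/N=C/c2ccccc2)s1` is yet to be measured. The change from compound 3 is hydrogen in place of hydroxy on an aromatic carbon. Among the measured compounds shown here, the steps that bear on it are those at the same aromatic carbon: no change at the digits printed from compound 2 to compound 3 (within the scatter), where hydrogen replaced methyl on the oxygen, and no change at the digits printed from compound 1 to compound 3 (within the scatter), where hydroxy replaced dimethylamino. Neither moved the read-out beyond the scatter, so removing the hydroxy altogether is expected to give no step beyond the scatter either, in no particular direction: the expected step is no change at the digits printed from compound 3 to compound 4 (within the scatter). Compound 4 is therefore estimated at 50%, with a range from 35% to 65%.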

Compound 4, a percentage reported as inhibition, in the whole organism at one dose (the size of the read-out at that dose, not a potency): 50%
Compound 4: middle estimate and measured number agree at the digits printed; low and high end bracket the measured number.
By their numbers in this assay, from the lowest: compounds 1, 2, 3 and 4 (each within the scatter of the next).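

In this assay, among the compounds shown here, the earlier compounds only exchanged one attached group for another on this aromatic carbon, whereas compound 4 carries hydrogen there and so tests whether any such group is needed. Removing each group gives the same answer: hydroxy (no change at the digits printed from compound 3 to compound 4 (within the scatter)), methoxy (no change at the digits printed from compound 2 to compound 4 (within the scatter)) and dimethylamino (no change at the digits printed from compound 1 to compound 4 (within the scatter)). At this dose, then, the read-out does not depend on having any of these three groups at this place, and the 4-hydroxyphenyl to phenyl change gives no separation; no measurement on hand offers an account of this flat result.

Still open, going by these compounds, is whether a chlorine, a nitro group, a carboxylic acid or a longer chain such as butoxy on this aromatic carbon would give a step beyond the scatter. A single dose also leaves open whether the four compounds would still stand level at other doses, and whether changes elsewhere on the shared core would move the read-out.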